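Diisopropylcarbamoyl on the ring carbon: working notes on the series

The compounds below may be only part of what the source reports. "The series", "measured", "known", "first", "only" and "open" are said of these compounds alone.

In a functional assay on HL-60 cells (Homo sapiens) for antiproliferative activity, read by MTT assay, with a stated time of 48 h (on this read-out higher numbers stand for weaker inhibition and lower numbers for stronger inhibition), compound 1 `CC(C)=CCC[C@]1(C)/C=C/[C@@H](OC(=O)C=C(C)C)[C@](C)(O)/C=C/C(=O)/C(CN2CCCC2)=C\C1` gives 160 nM while compound 2 `CC(C)=CCC[C@]1(C)/C=C/[C@@H](OC(=O)C=C(C)C)[C@](C)(O)/C=C/C(=O)/C(C[Si](C)(C)C(C)(C)C)=C\C1` gives 2770 nM and compound 3 `CSC(=S)OC/C1=C/C[C@](C)(CCC=C(C)C)/C=C/[C@@H](OC(=O)C=C(C)C)[C@](C)(O)/C=C/C1=O` gives 180 nM on the same scale. Compound 3 belongs to the low pair of these three numbers. That pair is tight (a 1.1-fold higher number from compound 1 to compound 3 (0.05 log units; within the scatter)) and the remaining compound stands far off (a 15-fold lower number from compound 2 to compound 3 (1.19 log units; beyond the scatter)).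

Compound 4 `CC(C)=CCC[C@]1(C)/C=C/[C@@H](OC(=O)C=C(C)C)[C@](C)(O)/C=C/C(=O)/C(C(=O)N(C(C)C)C(C)C)=C\C1` replaces the sulfur-bearing group of compound 3 with diisopropylcarbamoyl on a double-bonded ring carbon of the shared core (a group of 9 heavy atoms (7 carbon, 1 nitrogen, 1 oxygen; no ring) in place of a group of 6 heavy atoms (3 carbon, 1 oxygen, 2 sulfur; no ring), on a double-bonded ring carbon). The measured steps all swap groups on a saturated chain carbon bound to a double-bonded ring carbon, so none of them matches this change exactly. Among the measured compounds shown here, they show only that a swap there can leave the number within the scatter (a 1.1-fold higher number from compound 1 to compound 3 (0.05 log units; within the scatter)) or raise it strongly (a 17-fold higher number from compound 1 to compound 2 (1.24 log units; beyond the scatter)). The series holds no carbamoyl group at this place, so a rise of moderate size is expected, short of the large steps and with wide uncertainty. The expected step is a 3.9-fold higher number from compound 3 to compound 4 (0.59 log units; beyond the scatter) and points to weaker inhibition. In this assay compound 4 is estimated at 700 nM (expected range 150 nM to 3000 nM).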

Compound 4, half-maximal inhibitory concentration: 12700 nM
Compound 4: middle estimate off by 18-fold (1.26 log units), on the low side; measured number outside the range, above it.
By their numbers in this assay, from the lowest: compounds 1 and 3 (each within the scatter of the next); then compound 2; then compound 4.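

In this assay, diisopropylcarbamoyl on the double-bonded ring carbon gives the highest number of the four compounds (a 71-fold higher number from compound 3 to compound 4 (1.85 log units; beyond the scatter); a 79-fold higher number from compound 1 to compound 4 (1.90 log units; beyond the scatter)), and both steps exceed any step among the first three compounds. The number rises even against the silicon-bearing group of compound 2 (a 4.6-fold higher number from compound 2 to compound 4 (0.66 log units; beyond the scatter)), a modest step but beyond the scatter, so that group no longer marks the top of the range at this place. Compound 4 also alone carries its group directly on the double-bonded ring carbon, without the saturated chain carbon of compounds 1, 2 and 3, so the swap changes more than the end group and shows that the two together can cost far more than the earlier swaps suggested.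

The compounds shown leave open whether the rise follows the carbonyl, the two isopropyl groups or the missing chain carbon, which a primary carboxamide or a carboxylic acid on the same ring carbon, or a diisopropylaminomethyl group on the chain carbon, would help to separate. Nothing given here bears on the reason for the rise.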